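A Fluorine on the Benzyl Arm of Compound 1

The source may hold more compounds than are shown below. What is called first, only, known or untested is meant among the compounds shown, and "the series" means these compounds.

Compound 1 `O=C1CCc2ccc(OCCCN3CCCCC3)cc2N1Cc1ccccc1` gives 1.84 nM in an assay on cell membranes (strain Dunkin Hartley) for displacement of a labelled ligand from Sigma non-opioid intracellular receptor 1 (Cavia porcellus), read by scintillation counting, with a stated time of 180 min (on this read-out higher numbers stand for weaker inhibition and lower numbers for stronger inhibition), the lowest of the three numbers measured. Compound 2 `CN(C)CCCOc1ccc2c(c1)N(Cc1ccccc1)C(=O)CC2` gives 83.2 nM, and compound 3 `CCN(CC)CCCOc1ccc2c(c1)N(Cc1ccccc1)C(=O)CC2` gives 39.4 nM. The step of a 45-fold higher number from compound 1 to compound 2 (1.66 log units; beyond the scatter) and the step of a 21-fold higher number from compound 1 to compound 3 (1.33 log units; beyond the scatter) are both large, while a 2.1-fold lower number from compound 2 to compound 3 (0.32 log units; beyond the scatter) is modest; all three concern the amine on the saturated chain carbon. Compound 4 `O=C1CCc2ccc(OCCCN3CCCCC3)cc2N1Cc1ccc(F)cc1` differs from compound 1 by fluoro in place of hydrogen on an aromatic carbon. Among the measured compounds shown here, none of the measured steps touches this part of the molecule, so no measured step bears directly on it. With no comparable change among the measured compounds, the expected step is a 1.1-fold higher number from compound 1 to compound 4 (0.04 log units; within the scatter), that is, none beyond the scatter. Compound 4 is therefore estimated at 2 nM, within 0.8 nM to 5 nM.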

Compound 4, inhibition constant: 1.22 nM
Compound 4: the middle estimate sits 1.6-fold (0.21 log units) above what was measured; low and high end bracket the measured number.
By their numbers in this assay, from the lowest: compounds 4 and 1 (each within the scatter of the next); then compound 3; then compound 2.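

The change from benzyl to 4-fluorobenzyl gives a 1.5-fold lower number from compound 1 to compound 4 (0.18 log units; within the scatter), so in this assay this place on the benzyl arm accepts a fluoro with no step beyond the scatter. Among the compounds shown here, this is the first measured change away from the amine, and it leaves the low number of compound 1 in place, unlike the large steps seen at the amine. No evidence is available on what lies behind this result.

As far as these compounds go, whether a larger group such as chloro or methoxy at this place would also stay within the scatter remains open. So does whether fluoro would behave the same way alongside the diethylamino group of compound 3.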